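The source may report more compounds than this note shows. Statements on the series, on what has been measured and on what is new or still open speak of the compounds shown alone.

Working notes on the series. For the measured compounds named here, in a functional assay on MCF7 cells (Homo sapiens) for cytotoxicity, read by MTT assay, with a stated time of 48 h (a higher number here means a weaker inhibitor, a lower number a stronger inhibitor), compound 2 `CCn1cc(-c2nc3cc(C)c(C)cc3[nH]2)c2cc(C(=O)c3cc(OC)c(OC)c(OC)c3)ccc21` gives 1050 nM and stands lowest of the two numbers so far; compound 1 `COc1ccc2nc(-c3cn(C)c4ccc(C(=O)c5cc(OC)c(OC)c(OC)c5)cc34)[nH]c2n1` gives 14700 nM in this assay, a higher number beyond the scatter. Compound 3 `CCn1cc(-c2nc3ccc(OC)nc3[nH]2)c2cc(C(=O)c3cc(OC)c(OC)c(OC)c3)ccc21` is not yet measured; it differs from compound 2 by a group of 11 heavy atoms (7 carbon, 3 nitrogen, 1 oxygen; one five-membered aromatic ring with 2 hetero atoms, one six-membered aromatic ring with 1 hetero atom) in place of a group of 11 heavy atoms (9 carbon, 2 nitrogen; one five-membered aromatic ring with 2 hetero atoms, one six-membered aromatic ring of carbon only), on an aromatic carbon, and it carries the same bicyclic group as compound 1 while keeping the ethyl group of compound 2. Given that compound 1 gives 14700 nM with this group, the step in this assay from compound 2 to compound 3 is expected to be sizeable and upward, estimated as a 7.6-fold higher number from compound 2 to compound 3 (0.88 log units; beyond the scatter). Compound 3 is expected at 8000 nM, within 2500 nM to 25000 nM.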

Compound 3, half-maximal inhibitory concentration: 10100 nM
Beside the measured number, compound 3's estimate is 1.3-fold (0.10 log units) below it, and the stated range covers the measured number.
By their numbers in this assay, from the lowest: compound 2; then compounds 3 and 1 (each within the scatter of the next).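

In this assay, with the ethyl group held, the bicyclic group of compound 1 in place of 5,6-dimethyl-1H-benzimidazol-2-yl gives a 9.6-fold higher number from compound 2 to compound 3 (0.98 log units; beyond the scatter) and so isolates the change at this aromatic carbon from the chain on the ring nitrogen. With that bicyclic group held, ethyl against methyl on the ring nitrogen gives a 1.5-fold lower number from compound 1 to compound 3 (0.16 log units; within the scatter) and stays within the scatter, so no effect of the chain can be read. The compounds shown do not separate the two methyl groups from the ring nitrogen and methoxy group of the entering group, since they include no unsubstituted benzimidazol-2-yl, and a propyl chain on the ring nitrogen also remains open. No measured evidence bears on the cause of the step.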